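A few compounds are considered here, and "the series" means these few. Any claim that something is new, unique, unknown or untested is made for them only; others in the source may bear on it.

Compound 1 `Nc1nc2ccccc2c(=O)o1` carries a bare amino group on the shared core. In an assay on isolated protein for inhibition of complement C1r subcomponent (Homo sapiens) (a lower number here means a stronger inhibitor, a higher number a weaker inhibitor), compound 1 gives > 62500 nM, which is a limit of the measurement rather than a number. Compound 3 `Cc1cccc(C)c1Nc1nc2ccccc2c(=O)o1` likewise reaches only a limit, > 62500 nM. Compound 2 `O=c1oc(Nc2c(Cl)cccc2Cl)nc2ccccc12` gives 900 nM in this assay. Compound 1 therefore stands at the limit of > 62500 nM in this assay, at which 2 of the 3 values shown sit, so its true potency is not known, only that it is weak. Compound 4 `O=c1oc(Nc2nc[nH]n2)nc2ccccc12` differs from compound 1 by 1H-1,2,4-triazol-3-yl in place of hydrogen on a nitrogen on an aromatic ring. Among the measured compounds shown here, no measured pair shows this kind of change, so its direction rests on expectation alone. The expected step is an at least 2.5-fold lower number from compound 1 to compound 4 (0.39 log units; beyond the scatter), toward stronger inhibition. Compound 4 is estimated to give about 25000 nM in this assay, within a range from 2000 nM to 100000 nM.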

Compound 4, half-maximal inhibitory concentration: > 62500 nM
Compound 4 ended at the assay's limit; the forecaster's own chance of this, stated with the estimate: 55%; middle value at least 2.5-fold (0.39 log units) away from the limit.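

Compound 1 and compound 4 both stop at a limit of the measurement, and the step between them cannot be read. The compounds shown leave open whether 1H-1,2,4-triazol-3-yl in place of hydrogen changes inhibition at all.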